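The source may report more compounds than this note shows. Statements on the series, on what has been measured and on what is new or still open speak of the compounds shown alone.

compound 1 `CC1CCN(c2c(S(=O)(=O)c3ccc(Cl)cc3)cnc3ccc(F)cc23)CC1` — 80%
compound 2 `Cc1ccc2ncc(S(=O)(=O)c3ccc(C)c(Cl)c3)c(N3CCC(C)CC3)c2c1` — 91%
compound 3 `Cc1ccc(S(=O)(=O)c2cnc3ccc(F)cc3c2N2CCC(C)CC2)cc1C` — 92%

For the measured compounds named here, in an assay on isolated protein for displacement of a labelled ligand from metabotropic glutamate receptor 5 (Homo sapiens), with a stated time of 60 min, tested at 1 uM (a lower number here means less inhibition, a higher number more inhibition at the concentration tested (going by the name of the read-out)), compound 3 gives 92%, the highest of the three numbers; compound 2 sits within the scatter of it, while compound 1 sits lower, the only single-point step being a number 12 percentage points higher from compound 1 to compound 3 (beyond the scatter). Compound 4 `Cc1ccc(S(=O)(=O)c2cnc3ccc(F)cc3c2N2CCC(C)CC2)cc1Cl` differs from compound 3 by chloro in place of methyl on an aromatic carbon. This runs partway back toward the aryl group of compound 1, whose step to compound 3 was modest; compound 2, which carries the same 3-chloro-4-methylphenyl on the sulfonyl sulfur though on a different core, shows a value within the scatter of compound 3. The expected change is therefore a number 4 percentage points lower from compound 3 to compound 4 (within the scatter), none beyond the scatter. Compound 4 is estimated at 88%, range 78% to 95%.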

Compound 4, a percentage reported as inhibition, at one concentration (the size of the read-out at that concentration, not a potency): 91%
Estimate against measurement, compound 4: 3 percentage points below, and the stated range covers the measured number.
By their numbers in this assay, from the lowest: compound 1; then compounds 2, 4 and 3 (each within the scatter of the next).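

In this assay, chloro and methyl at this aromatic carbon, ortho to a methyl group, are not separated on the shared core (a number 1 percentage points lower from compound 3 to compound 4 (within the scatter)). Fluoro in place of methyl on the core also leaves the number unmoved when the sulfonyl aryl group is 3-chloro-4-methylphenyl (no change at the digits printed from compound 2 to compound 4 (within the scatter)), and that aryl group, like 3,4-dimethylphenyl, stands clear of 4-chlorophenyl (a number 11 percentage points higher from compound 1 to compound 4 (beyond the scatter)). No measurement here accounts for these steps. Still open, on these data alone, is whether methoxy, a carboxylic acid or an amine at this aromatic carbon would hold the number. Readings at one concentration also leave open whether compound 2, compound 3 and compound 4 would give a stronger or weaker effect than one another at any other concentration.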